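Replacing the chloro group on compound 1 with a cyclic sulfanyl group

The source may hold more compounds than are shown below. What is called first, only, known or untested is meant among the compounds shown, and "the series" means these compounds.

The measured compounds:
compound 1 `Cn1c(-c2ccc(NC(=O)CCl)cc2)nc(-c2ccccc2)c1-c1ccccc1` gives 23.7%;
compound 2 `Cn1c(-c2ccc(NC(=O)CSc3nc4ccccc4s3)cc2)nc(-c2ccccc2)c1-c1ccccc1` gives 47.2%;
compound 3 `Cn1cnnc1SCC(=O)Nc1ccc(-c2nc(-c3ccccc3)c(-c3ccccc3)n2C)cc1` gives 59.1%.

All three share one core and differ only in the group on a saturated chain carbon bound to a carbonyl carbon. In a functional assay on HT-29 cells (Homo sapiens) for cytotoxicity, read by MTT assay, with a stated time of 24 h, tested at 16 ug/mL (a higher number here means a stronger effect of the compound at the concentration tested, a lower number a weaker effect), compound 1 stands lowest of the three numbers; the nearest is compound 2 and the furthest is compound 3, both beyond the scatter.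

Compound 4 `Cn1c(-c2ccc(NC(=O)CSC3=NCCS3)cc2)nc(-c2ccccc2)c1-c1ccccc1` has not been measured. It differs from compound 1 as follows: a group of 6 heavy atoms (3 carbon, 1 nitrogen, 2 sulfur; one five-membered non-aromatic ring with 2 hetero atoms) in place of one chlorine atom, on a saturated chain carbon bound to a carbonyl carbon

Among the compounds with values here, two measured steps bear on this change, since each also replaces the chloro group with a sulfanyl-linked ring: a number 23.5 percentage points higher from compound 1 to compound 2 (beyond the scatter) and a number 35.4 percentage points higher from compound 1 to compound 3 (beyond the scatter). The choice of ring mattered in turn, as shown by a number 11.9 percentage points higher from compound 2 to compound 3 (beyond the scatter). A rise beyond the scatter is therefore expected for compound 4, of about a number 24.3 percentage points higher from compound 1 to compound 4 (beyond the scatter), and compound 4 is estimated at 48%, within a range of 30% to 66%.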

Compound 4, a percentage reported as activity, at one concentration (the size of the read-out at that concentration, not a potency): 43.3%
Estimate against measurement, compound 4: 4.7 percentage points above; measured number inside the range.
By their numbers in this assay, from the lowest: compound 1; then compounds 4 and 2 (each within the scatter of the next); then compound 3.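

A sulfanyl-linked ring at this saturated chain carbon need not be aromatic: a five-membered non-aromatic ring in place of chloro still gives a number 19.6 percentage points higher from compound 1 to compound 4 (beyond the scatter) in this assay as its read-out. Set against the larger two-ring benzothiazolyl group, the same ring gives a number 3.9 percentage points lower from compound 2 to compound 4 (within the scatter) and so cannot be told apart from it, while against the methyltriazolyl group it gives a number 15.8 percentage points lower from compound 3 to compound 4 (beyond the scatter) and leaves compound 3 highest of the four. Nothing shown here explains why these rings differ.

Whether the sulfur link itself matters stays open, as the compounds shown do not tell how a morpholine, an amine joined through its nitrogen, would compare on this carbon. Also open, going by these compounds, is whether an open-chain ethylsulfanyl group would match the rings.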